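A Double Bond Turned in a Weak Series

A few compounds are considered here, and "the series" means these few. Any claim that something is new, unique, unknown or untested is made for them only; others in the source may bear on it.

In a functional assay on HCT-116 cells (Homo sapiens) for inhibition (a higher number here means a weaker inhibitor, a lower number a stronger inhibitor), compound 1 `CN(C)c1ccc(/C=C\c2ccc3ccccc3c2)cc1` gives 3660 nM, a measured number. Compound 2 `C(=C/c1ccco1)\c1ccc2ccccc2c1` is reported only as a limit of the assay, > 5000 nM. Its exact position is therefore unknown, and (the limit of > 5000 nM in this assay, at which 1 of the 2 values shown sits).

Compound 3 `C(=C\c1ccco1)\c1ccc2ccccc2c1` has the same atoms and bonds as compound 2: the two compounds have the same atoms and bonds and differ only in configuration as drawn: 1 of 1 stereo elements differ; a double bond is drawn E in compound 2 and Z in compound 3. For the measured compounds named here, no measured pair in this assay shows what this change in configuration does, so any expectation rests on thin ground. Going by the values given here, the one firm reference is compound 1, with its value of 3660 nM, and compound 3 is expected to land in that neighbourhood. A modest move towards a stronger inhibitor is expected, with the estimated step of an at least 1.4-fold lower number from compound 2 to compound 3 (0.15 log units; that floor lies within the scatter). A reading that again gives only a limit would not be surprising. Compound 3 is estimated at 3500 nM, with an expected range of 900 nM to 10000 nM.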

Compound 3, half-maximal inhibitory concentration: > 5000 nM
Compound 3: only a limit was reported; the forecaster's own chance of this, stated with the estimate: 35%; middle value at least 1.4-fold (0.15 log units) away from the limit.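

Compound 3, like compound 2, is reported in this assay only as a limit of the assay, so no step between the two can be read: the limit of > 5000 nM in this assay, at which 2 of the 3 values shown sit.

Going by these compounds, whether the double bond drawn E in compound 2 and Z in compound 3 changes inhibition at all remains open.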